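This account rests on a few compounds, and the source may have more. Where it says the series, first, only, none or still open, it means among the compounds named here.

Among the measured compounds shown here, compound 1 `O=C(NCc1ccc(CNS(=O)(=O)c2ccccc2)cc1)c1ccc([N+](=O)[O-])cc1` is the one compound in this set that returns a number in an assay on MDA-MB-231 cells for binding affinity to C-X-C chemokine receptor type 4 (Homo sapiens), read by immunofluorescence and microscopy, with stated times of 10 min and 30 min; on this read-out lower numbers stand for an effect already at smaller amounts and higher numbers for an effect only at larger amounts of compound: in that assay compound 1 gives 100 nM. Compound 2 `Cc1ccc(S(=O)(=O)NCc2ccc(CNC(=O)c3ccccc3)cc2)cc1` does not return a number. In this assay compound 2 gives > 1000 nM, which is a limit of the assay and not a measured value. Compound 1 thus stands alone with a number, the other entry sitting at the limit of > 1000 nM in this assay, at which 1 of the 2 values shown sits.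

Compound 3 `O=C(NCc1ccc(CNS(=O)(=O)c2ccccc2)cc1)c1ccccc1Cl` has not yet been measured. It differs from compound 1 in a single place: 2-chlorophenyl in place of 4-nitrophenyl on a carbonyl carbon. For the measured compounds named here, no step between two measured compounds covers this change, so nothing in the set fixes its size directly. The expectation is that compound 3 loses ground against compound 1, an estimated step of a 5.0-fold higher number from compound 1 to compound 3 (0.70 log units; beyond the scatter), clearly beyond the usual scatter, with a real chance that the assay reports only a limit, as it did for the entry at the limit of > 1000 nM in this assay, at which 1 of the 2 values shown sits. Compound 3 is accordingly expected at 500 nM, with a likely range from 150 nM to 3000 nM.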

Compound 3, effective concentration (reported as EC, without a stated level of effect): 10 nM
For compound 3 the middle estimate is 50-fold (1.70 log units) above the measured one, and the stated range ends above it.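

In this assay, the group on a carbonyl carbon whose other neighbours are an amide-type nitrogen proves to be a place where a single change moves the read-out well past the usual variation: putting 2-chlorophenyl in place of 4-nitrophenyl gives a 10-fold lower number from compound 1 to compound 3 (1.00 log units; beyond the scatter). Among the compounds shown here, until now compound 1 was the only compound with a number, so it could not be told whether that number depended on 4-nitrophenyl; compound 3 carries no nitro group and still returns a number, showing that, on this core, 4-nitrophenyl is not required for a number in this assay. Nothing shown gives a measured property that would explain the size of this step.

The compounds shown leave open whether the step follows from the chlorine, from where it sits on the ring or simply from the loss of the nitro group, a question that 4-chlorophenyl, 2-nitrophenyl or unsubstituted phenyl on the same carbonyl carbon would address. Also open, from the compounds shown here alone, is whether this place accepts anything other than a substituted phenyl, such as a pyridine ring, a cyclohexyl group or a longer alkyl chain.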